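This account rests on a few compounds, and the source may have more. Where it says the series, first, only, none or still open, it means among the compounds named here.

Measured so far in an in vitro assay on LLC-PK1 cells for displacement of a labelled ligand from growth hormone secretagogue receptor type 1 (Homo sapiens); on this read-out higher numbers stand for weaker inhibition and lower numbers for stronger inhibition:
compound 1, `COc1ccc(Cn2c(CCc3ccccc3)nnc2[C@H](NC(=O)C(C)(C)N)c2c[nH]c3ccccc23)cc1` — 11 nM
compound 2, `COc1ccc(Cn2c(CCc3ccccc3)nnc2[C@H](NC(=O)c2cnccn2)c2c[nH]c3ccccc23)c(OC)c1` — 5 nM

In this assay compound 2 stands lowest of the two numbers, and its nearest neighbour is compound 1, whose value is higher by a margin beyond the scatter. Within the data shown here, compound 1 and compound 2 differ from each other in more than one place, so their two values show only that compound 2 inhibits more strongly; no single change can be credited.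

Compound 3, `COc1ccc(Cn2c(CCc3ccccc3)nnc2[C@H](NC(=O)c2cnccn2)c2c[nH]c3ccccc23)cc1`, is not yet measured in this assay. It differs from compound 2 in one place: hydrogen in place of methoxy on an aromatic carbon. Among the measured compounds shown here, no pair among the measured compounds isolates this change, so there is no measured step to lean on. The change is small, a methoxy leaving an aromatic carbon while everything else stays as in compound 2, and the expectation is a small step from compound 2 to compound 3, a 1.4-fold higher number from compound 2 to compound 3 (0.15 log units; within the scatter), leaning toward a higher number but quite possibly none beyond the scatter. On that basis compound 3 is estimated at 7 nM in this assay, with a range from 3 nM to 18 nM.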

Compound 3, half-maximal inhibitory concentration: 14 nM
For compound 3 the middle estimate is 2.0-fold (0.30 log units) below the measured one, and the stated range covers the measured number.
By their numbers in this assay, from the lowest: compound 2; then compounds 1 and 3 (each within the scatter of the next).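

In this assay, taking 2,4-dimethoxybenzyl to 4-methoxybenzyl gives a 2.8-fold higher number from compound 2 to compound 3 (0.45 log units; beyond the scatter), the first measured sign that the methoxy on this aromatic carbon, ortho to a large group, makes a difference to the number. The step is modest and rests on this single pair, but it goes beyond the scatter, which the comparison of compound 1 with compound 2 could not show because those two differ in more than one place. Compound 3 also gives a one-place link to compound 1: with the 4-methoxybenzyl group held constant, putting pyrazin-2-yl in place of 1-amino-1-methylethyl on the carbonyl carbon gives a 1.3-fold higher number from compound 1 to compound 3 (0.10 log units; within the scatter) and so separates these two groups by no more than the scatter, while nothing measured on these compounds accounts for either step.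

On these data alone, it remains open whether a fluorine, a hydroxyl or an ethoxy on that same aromatic carbon would keep the number as low as the methoxy of compound 2 does. As far as these compounds go, it is equally open whether the second methoxy would give a similar step with 1-amino-1-methylethyl on the carbonyl carbon, where only the 4-methoxybenzyl form, compound 1, stands here.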